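Swapping a thiophene for a furan on a triazole

The source may hold more compounds than are shown below. What is called first, only, known or untested is meant among the compounds shown, and "the series" means these compounds.

Of the compounds shown here, two have been tested in a functional assay on ECV-304 cells (Homo sapiens), read by MTT assay, with stated times of 24 h and 12 h, tested at 12.5 uM; a higher number here means a stronger effect of the compound at the concentration tested, a lower number a weaker effect. Compound 1, `Cc1nc(C)c(CNC(=O)CN2CCCC2=O)nc1C`, gives -35.8%, a reading that falls below zero. Within the data shown here, compound 2, `Cc1nc(C)c(CSc2nnc(-c3cccs3)n2N)nc1C`, gives 36.2% and so shows the highest number of the two; the only other value, that of compound 1, lies a distance below it that is beyond the usual scatter of repeated measurements.

The next compound keeps almost all of compound 2. Compound 3, `Cc1nc(C)c(CSc2nnc(-c3ccco3)n2N)nc1C`, differs in a single place: furan-2-yl in place of thiophen-2-yl on an aromatic carbon. The ring that leaves and the ring that enters are both five-membered aromatic rings with one hetero atom, each carrying one hydrogen-bond acceptor and no donor, and both sit on the same aromatic carbon of the ring with three nitrogen atoms. Among the measured compounds shown here, no pair of measured compounds shows what such a swap does in this assay, so the size of the step can only be guessed. A small step, at most near the edge of the scatter, with no clear direction, seems most likely.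

Compound 3 is therefore expected to give about 30%, with a plausible range from 8% to 52%. This estimate means an expected step of a number 6.2 percentage points lower from compound 2 to compound 3 (within the scatter).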

Compound 3, a percentage reported as activity, at one concentration (the size of the read-out at that concentration, not a potency): 19%
Compound 3: middle estimate off by 11 percentage points, on the high side; measured number inside the range.
By their numbers in this assay, from the lowest: compound 1; then compound 3; then compound 2.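

Among these compounds, this is the first pair of measured compounds that differ in only one place, and in this assay it shows that the group on this aromatic carbon of the five-membered aromatic ring with 3 nitrogen matters: furan-2-yl in place of thiophen-2-yl gives a number 17.2 percentage points lower from compound 2 to compound 3 (beyond the scatter), a modest step. The two groups match in everything counted here, with 5 heavy atoms each, one five-membered aromatic ring with 1 hetero atom and 1 hydrogen-bond acceptor, and the visible difference is that ring oxygen stands where ring sulfur stood, so even an exchange this close moves the read-out beyond the usual scatter. Nothing measured here explains the drop.

A single exchange cannot show how the read-out would respond to a larger or different group at this position, such as a phenyl ring, a pyridine ring or a short alkyl chain. The compounds shown also leave open what happens when the amino group on the neighbouring ring atom gives way to a hydrogen or a methyl group.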